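The source may report more compounds than this note shows. Statements on the series, on what has been measured and on what is new or still open speak of the compounds shown alone.

Of the compounds shown here, three have so far been tested in a functional assay with Alpha-1D adrenergic receptor (Homo sapiens) as the target, read by calcium flux; a higher number here means a larger maximal response, a lower number a smaller maximal response. Compound 1 `Cn1cc(-c2ccccc2NCC2=NCCN2)cn1` gives 0%, compound 3 `CCn1cc(-c2ccccc2NCC2=NCCN2)cn1` gives 0%, and compound 2 `CC(C)n1nccc1-c1ccccc1NCC1=NCCN1` gives 0%, so none of the three produces a response in this assay.

Compound 3 and compound 1 differ in one place only, (hydrogen in place of methyl on a saturated chain carbon bound to an aromatic nitrogen), and that step, no change at the digits printed from compound 3 to compound 1 (within the scatter), left the response untouched. Compound 4 `CCn1nccc1-c1ccccc1NCC1=NCCN1` has not yet been measured; it differs from compound 2 by hydrogen in place of methyl on a saturated chain carbon bound to an aromatic nitrogen and a saturated chain carbon. This is the same kind of change as from compound 3 to compound 1, though the surroundings are not identical: in compound 2 the carbon that loses the methyl is bound to an aromatic nitrogen and a saturated chain carbon, whereas in compound 3 it is bound to an aromatic nitrogen alone. How the core of compound 2 differs from the core of compound 3 is not broken down here.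

The step from compound 2 to compound 4 is expected to be no change at the digits printed from compound 2 to compound 4 (within the scatter), because compound 2 gives 0% and the comparable earlier step from compound 3 to compound 1 was no change at the digits printed from compound 3 to compound 1 (within the scatter). For compound 4 the expected value in this assay is therefore 0%, most likely between 0% and 8%.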

Compound 4, largest response reached (reported as maximal response), in percent of the reference or control that the assay uses: 0%
The estimate for compound 4 equals the measured number at the digits printed; measured number inside the range.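

In this assay, removing the methyl so that isopropyl becomes ethyl gives no change at the digits printed from compound 2 to compound 4 (within the scatter), and this step agrees with the one seen earlier on the other core: the same change on two cores in this assay, no change at the digits printed (within the scatter) from compound 3 to compound 1 and no change at the digits printed (within the scatter) from compound 2 to compound 4, 0 percentage points apart, within the scatter of two such steps. Within these four compounds, then, the change has the same outcome on both cores. This does not show that the change is harmless or that it would carry over in general, since compound 2 and compound 4 both give no response, as do compound 1 and compound 3, and steps among silent compounds say nothing about how the change would act on a compound that does produce a response.

The compounds shown leave open whether anything in this series produces a response in this assay at all. They also leave open whether a longer chain such as butyl, or an amine or a carboxylic acid in place of the ethyl, would give a value different from that of compound 4, 0%.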